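Methoxy on the fused ring: the next step in the series

The source may report more compounds than this note shows. Statements on the series, on what has been measured and on what is new or still open speak of the compounds shown alone.

Of the compounds shown here, two of the shared core carry numbers so far. Compound 1 `Nc1ncc(/C=C2\COc3ccccc3C2=O)cn1` gives 18300 nM in an assay on BTI-TN-5B1-4 cells for inhibition of Amine oxidase [flavin-containing] B (Homo sapiens), read by fluorescence and Amplex Red, using microsomes, with a stated time of 15 min; on this read-out higher numbers stand for weaker inhibition and lower numbers for stronger inhibition. Compound 2 `CN(C)c1ncc(/C=C2\COc3ccccc3C2=O)cn1` gives 241 nM in this assay. For the measured compounds named here, the single measured step, a 76-fold lower number from compound 1 to compound 2 (1.88 log units; beyond the scatter), is large and beyond the scatter. Going by the values given here, compound 2 therefore stands lowest of the two numbers, with compound 1 as its only neighbour.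

The next compound, compound 3 `COc1ccc2c(c1)OC/C(=C\c1cnc(N(C)C)nc1)C2=O`, differs from compound 2 by methoxy in place of hydrogen on an aromatic carbon. Among the compounds with values here, no measured step bears on this change: the only step in hand, a 76-fold lower number from compound 1 to compound 2 (1.88 log units; beyond the scatter), concerns dimethylamino in place of amino on the other ring system and says nothing about a methoxy on the fused ring. For this assay the expectation is accordingly a step of no set direction, none beyond the scatter, with a wide band of uncertainty around it. Compound 3 is expected to give 250 nM, between 60 nM and 1000 nM. The expected step, a 1.0-fold higher number from compound 2 to compound 3 (0.02 log units; within the scatter), thus amounts to close to no change.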

Compound 3, half-maximal inhibitory concentration: 10400 nM
Compound 3: the middle estimate sits 42-fold (1.62 log units) below what was measured; the whole stated range lies below it.
By their numbers in this assay, from the lowest: compound 2; then compounds 3 and 1 (each within the scatter of the next).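

In this assay the step of a 43-fold higher number from compound 2 to compound 3 (1.64 log units; beyond the scatter) shows that this aromatic carbon of the shared core, meta to a fused ring and para to a fused ring, is far from indifferent to substitution: methoxy, with only 2 heavy atoms, in place of hydrogen gives a large change. Set beside a 76-fold lower number from compound 1 to compound 2 (1.88 log units; beyond the scatter) it also shows that a second place on the shared core moves the read-out by a large step, here towards weaker inhibition rather than stronger. No measurement in hand accounts for this step.

Going by these compounds, it stays open whether the step belongs to methoxy in particular or to any group at this carbon, which a fluorine, a hydroxy or a longer chain such as ethoxy at the same place would help to separate. Also open, on these data alone, is whether methoxy on the other aromatic carbons of the same ring gives a step of this size, and whether the step at this carbon holds when amino stands in place of dimethylamino.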